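Series notes: carboxy to acetyl on the shared core

This account rests on a few compounds, and the source may have more. Where it says the series, first, only, none or still open, it means among the compounds named here.

compound 1 `O=C(O)c1ccc2c(O)c(C(=O)O)cnc2c1`: 1070000 nM
compound 2 `O=C(O)c1cnc2cc(OCCOc3ccc(Br)cc3)ccc2c1O`: 5130 nM
compound 3 `O=C(O)c1cnc2cc(OCCc3ccc(Br)cc3)ccc2c1O`: 2510 nM

In an assay on isolated protein with malate dehydrogenase, mitochondrial (Sus scrofa) as the target (a lower number here means a stronger inhibitor, a higher number a weaker inhibitor), compound 1 gives the highest number of the three; compound 2 lies a long way lower, and compound 3 lower still. Compound 4 `CC(=O)c1ccc2c(O)c(C(=O)O)cnc2c1` differs from compound 1 by methyl in place of hydroxy on a carbonyl carbon. Among the measured compounds shown here, the one measured step, a 2.0-fold lower number from compound 2 to compound 3 (0.31 log units; beyond the scatter), changes the tail of the ether chain on the shared core and leaves the carboxy group untouched, so it says nothing about this change; no measured pair does. With nothing to build on, the expected step is a 1.1-fold lower number from compound 1 to compound 4 (0.03 log units; within the scatter), a change not expected to go beyond the scatter, with a wide range. The estimate for compound 4 is 1000000 nM, between 200000 nM and 5000000 nM.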

Compound 4, half-maximal inhibitory concentration: 912000 nM
The estimate for compound 4 lay 1.1-fold (0.04 log units) above the measured number, and the stated range covers the measured number.
By their numbers in this assay, from the lowest: compound 3; then compound 2; then compounds 4 and 1 (each within the scatter of the next).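

In this assay, the change from carboxy to acetyl is a 1.2-fold lower number from compound 1 to compound 4 (0.07 log units; within the scatter), so at this position acetyl can take over from carboxy without the number moving beyond the scatter. The hydrogen-bond donor of the hydroxy can therefore go with no measurable consequence in this pair. Nothing available explains this flat step.

As far as these compounds go, whether a primary amide or a phenyl ketone at this place would move the number remains open. So does whether the same change stays flat on a compound carrying the 4-bromophenyl chain of compound 3.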